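Benzoyl in place of methyl on the ring nitrogen

A few compounds are considered here, and "the series" means these few. Any claim that something is new, unique, unknown or untested is made for them only; others in the source may bear on it.

The measured compounds in an assay on HEK293 cells for agonist activity at Toll-like receptor 8 (Homo sapiens), read by a luciferase reporter, with a stated time of 6 h; a higher number here means that more compound is needed for the effect, a lower number that less compound is needed:
- Compound 1 `CCCCNc1nc(N)nc2c1CN(Cc1ccccc1)CC2` gives 0.06 uM.
- Compound 2 `CCCCNc1nc(N)nc2c1CN(C)CC2` gives 0.03 uM.
- Compound 3 `CCCCNc1nc(N)nc2c1CCN(C)C2` gives 0.2 uM.

Compound 2 has the lowest of the three numbers. Its nearest neighbour is compound 1, and the step of a 2.0-fold lower number from compound 1 to compound 2 (0.30 log units; within the scatter) lies within the scatter, so the two cannot be ordered. Compound 3, which carries the methyl on a nitrogen at another place in the saturated ring, stands beyond the scatter from compound 2.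

Compound 4 `CCCCNc1nc(N)nc2c1CN(C(=O)c1ccccc1)CC2` is not yet measured. It differs from compound 2 in one place: benzoyl in place of methyl on an amine nitrogen in a ring.

Among the measured compounds shown here, only one measured step touches this nitrogen, the step of a 2.0-fold lower number from compound 1 to compound 2 (0.30 log units; within the scatter), which shows that a phenyl on the carbon bound to this nitrogen changes little. Benzoyl brings a carbonyl directly onto the nitrogen, and no measured pair shows such a change, so the expectation is loose. Compound 4 is expected to sit somewhat higher than compound 2, with the estimated step of a 3.3-fold higher number from compound 2 to compound 4 (0.52 log units; beyond the scatter). The estimate for compound 4 is 0.1 uM, within a range from 0.02 uM to 0.6 uM.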

Compound 4, minimum effective concentration: 1.4 uM
Compound 4: middle estimate off by 14-fold (1.15 log units), on the low side; the whole stated range lies below it.
By their numbers in this assay, from the lowest: compounds 2 and 1 (each within the scatter of the next); then compound 3; then compound 4.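

In this assay, among the compounds shown here, benzoyl in place of methyl on the amine nitrogen in a ring gives a 47-fold higher number from compound 2 to compound 4 (1.67 log units; beyond the scatter) and so shows that this position is far less forgiving than the earlier compounds suggested. Benzoyl in place of benzyl gives a 23-fold higher number from compound 1 to compound 4 (1.37 log units; beyond the scatter) as well, and since both groups carry a six-membered aromatic ring of carbon only, the large rise in this pair goes with the carbonyl on the nitrogen and not with the ring. Nothing available explains this rise.

From the compounds shown here alone, whether acetyl on this nitrogen brings a rise of similar size, which would tie it to the carbonyl without any ring, remains open. So does the effect of a plain hydrogen on this nitrogen, or of a urea or a sulfonamide built on it.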